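Notes on the step from compound 2 to compound 3

The compounds below may be only part of what the source reports. "The series", "measured", "known", "first", "only" and "open" are said of these compounds alone.

Two compounds have a result in a functional assay (Homo sapiens); a lower number here means a stronger inhibitor, a higher number a weaker inhibitor. Compound 1 `C/C(=C\CO)CC1=CC(=O)C(C)(C)O1` gives 15.2 ug/mL. Compound 2 `COc1ccccc1C1=CC(=O)CO1` reaches only the limit of this assay, > 100 ug/mL, so no number is known for it. Compound 2 stands at the limit of > 100 ug/mL in this assay, at which 1 of the 2 values shown sits. Going by the values given here, compound 1 and compound 2 differ in more than one place, and their two values show only that compound 1 has a number while compound 2 does not; no measured step exists.

Compound 3 `O=C1C=C(c2ccccc2)OC1` is not yet measured. It differs from compound 2 by hydrogen in place of methoxy on an aromatic carbon. Among the compounds with values here, no measured pair tells how this change acts in this assay, so the step is expected to be a number no higher from compound 2 to compound 3 (the limit leaves the size open), none beyond the scatter. Compound 3 is expected to give about 100 ug/mL, with a range from 40 ug/mL to 300 ug/mL, and this assay may well again report only a limit for compound 3.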

Compound 3, concentration for 50% inhibition: 31.2 ug/mL
Beside the measured number, compound 3's estimate is 3.2-fold (0.51 log units) above it; measured number below the stated range.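

In this assay, going by these compounds alone, hydrogen in place of methoxy on this aromatic carbon, ortho to a group of 6 heavy atoms, gives an at least 3.2-fold lower number from compound 2 to compound 3 (0.50 log units; beyond the scatter), the only measured step. The methoxy is therefore not needed here for a measurable result, as compound 3, with hydrogen at this position, gives 31.2 ug/mL. The result for compound 2, > 100 ug/mL, is a limit of the assay and not a number, and the full size of the step stays open because of it: the limit of > 100 ug/mL in this assay, at which 1 of the 3 values shown sits.

The compounds shown leave open whether another group on this aromatic carbon, such as an amine, a hydroxyl or a longer alkoxy chain, would give a number in this assay. They also leave open how methoxy acts at other places on the aromatic ring, and compound 1 differs from the others in more than one place, so it cannot settle either question.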